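Acetamido on the Fused Ring: Forecasting Unbound Fraction

The compounds below may be only part of what the source reports. "The series", "measured", "known", "first", "only" and "open" are said of these compounds alone.

Compound 1 `CCCCN(c1nc2ccccc2o1)[C@H](C)c1ccc(-c2ccccc2-c2nnn[nH]2)cc1` stands lowest of the three compounds measured in an ADME assay on the whole organism (plasma, Macaca fascicularis) for protein binding, read by LC-MS, using equilibrium dialysis and cassette dosing, with a stated time of 24 h, at a dose of 1 mg/kg by the oral route (a lower number here means a smaller unbound share, a higher number a larger unbound share of the compound), where compound 1 gives 0.000713. Its nearest neighbour is compound 3 `CCCCN(c1nc2c(CO)cccc2o1)[C@H](C)c1ccc(-c2ccccc2-c2nnn[nH]2)cc1`, which in this assay gives 0.00112; the step of a 1.6-fold higher number from compound 1 to compound 3 (0.20 log units; within the scatter) lies within the scatter. Furthest off is compound 2 `CCCCN(c1nc2c(-c3nccn3C)cccc2o1)[C@H](C)c1ccc(-c2ccccc2-c2nnn[nH]2)cc1`, which in this assay gives 0.00299; the step of a 4.2-fold higher number from compound 1 to compound 2 (0.62 log units; beyond the scatter) is beyond the scatter, as is the step of a 2.7-fold lower number from compound 2 to compound 3 (0.43 log units; beyond the scatter).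

Compound 4 `CCCCN(c1nc2c(NC(C)=O)cccc2o1)[C@H](C)c1ccc(-c2ccccc2-c2nnn[nH]2)cc1` differs from compound 1 by acetamido in place of hydrogen on an aromatic carbon. Going by the values given here, two measured steps bear on this change, each placing a group on an aromatic carbon of the core of compound 1: a 4.2-fold higher number from compound 1 to compound 2 (0.62 log units; beyond the scatter) and a 1.6-fold higher number from compound 1 to compound 3 (0.20 log units; within the scatter). Both run upward, the larger group giving the larger step. The acetamido group, with its four heavy atoms, is intermediate in size between hydroxymethyl and the 1-methyl-1H-imidazol-2-yl group, so a modest upward step is expected, of the order of a 1.8-fold higher number from compound 1 to compound 4 (0.26 log units; within the scatter), which may or may not clear the scatter. Compound 4 is therefore estimated to give 0.0013 in this assay, within a range from 0.0006 to 0.003.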

Compound 4, unbound fraction: 0.00102
Beside the measured number, compound 4's estimate is 1.3-fold (0.11 log units) above it; measured number inside the range.
By their numbers in this assay, from the lowest: compounds 1, 4 and 3 (each within the scatter of the next); then compound 2.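

At this position on the shared core, acetamido does not separate from hydrogen in this assay: the step is a 1.4-fold higher number from compound 1 to compound 4 (0.16 log units; within the scatter) and stays inside the scatter. It does not separate from hydroxymethyl either, with a 1.1-fold lower number from compound 3 to compound 4 (0.04 log units; within the scatter) as the step, so a second non-ring group placed on this aromatic carbon joins compounds 1 and 3 as one group of values. Compound 2 alone now stands apart from all three others, as a 2.9-fold lower number from compound 2 to compound 4 (0.47 log units; beyond the scatter) joins the earlier 2.7-fold lower number from compound 2 to compound 3 (0.43 log units; beyond the scatter) and a 4.2-fold higher number from compound 1 to compound 2 (0.62 log units; beyond the scatter) beyond the scatter, and no measurement at hand accounts for this separation.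

The compounds shown leave open whether the step belongs to the 1-methyl-1H-imidazol-2-yl group in particular or would also appear with another ring on this carbon, such as phenyl, pyridyl or an imidazole without its methyl. They also leave open what a primary amine, a carboxylic acid or a longer chain such as butanamido would give here, and whether any of these groups would behave alike on another aromatic carbon of the six-membered ring.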